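This account rests on a few compounds, and the source may have more. Where it says the series, first, only, none or still open, it means among the compounds named here.

Measured in a functional assay on CFPAC-1 cells (Homo sapiens) for antiproliferative activity, read by MTT assay, with a stated time of 72 h; a lower number here means a stronger inhibitor, a higher number a weaker inhibitor:
- compound 1 `O=C1O[C@H]([C@@H](O)Cn2cc(-c3cc(F)cc(F)c3)nn2)C(OCc2ccccc2)=C1OCc1ccccc1`: 62400 nM
- compound 2 `C[Si](C)(C)c1cn(C[C@H](O)[C@H]2OC(=O)C(OCc3ccccc3)=C2OCc2ccccc2)nn1`: 52600 nM

Within the data shown here, compound 2 lies within the scatter of compound 1, the only other measured compound, so neither stands apart in this assay. Next is compound 3 `O=C1O[C@H]([C@@H](O)Cn2cc(CCO)nn2)C(OCc2ccccc2)=C1OCc1ccccc1`, where 2-hydroxyethyl replaces the silicon-bearing group on an aromatic carbon of a five-membered aromatic ring with 3 nitrogen: a group of 3 heavy atoms (2 carbon, 1 oxygen; no ring) in place of a group of 4 heavy atoms (3 carbon, 1 silicon; no ring), on an aromatic carbon. Among the measured compounds shown here, only one measured step bears on this change, an exchange at the same aromatic carbon: a 1.2-fold lower number from compound 1 to compound 2 (0.07 log units; within the scatter). That exchange stayed within the scatter despite the difference between the two groups, so no step beyond the scatter is expected here. For the measured compounds named here, the 2-hydroxyethyl group has no measured precedent on that carbon, which keeps the range wide. The expected step is a 1.1-fold higher number from compound 2 to compound 3 (0.06 log units; within the scatter). In this assay, the estimate for compound 3 is 60000 nM, with an expected range of 20000 nM to 150000 nM.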

Compound 3, half-maximal inhibitory concentration: > 100000 nM
Compound 3 gave a limit, no number (the forecaster's own chance of this, stated with the estimate: 20%); middle value at least 1.6-fold (0.22 log units) away from the limit.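

In this assay compound 3 gives a limit and not a number: the limit of > 100000 nM in this assay, at which 1 of the 3 values shown sits. On the aromatic carbon of the five-membered aromatic ring with 3 nitrogen, 2-hydroxyethyl gives an at least 1.9-fold higher number from compound 2 to compound 3 (0.27 log units; that floor lies within the scatter), and the same group in place of 3,5-difluorophenyl gives an at least 1.6-fold higher number from compound 1 to compound 3 (0.20 log units; that floor lies within the scatter). Both changes therefore have only a floor with no upper bound, unlike the earlier exchange at this carbon, and neither floor establishes a loss beyond the scatter.

The compounds shown leave open how far compound 3 truly lies from the other two, and whether the hydroxyl or the chain of 2-hydroxyethyl matters at this carbon. A plain ethyl group, an amine, a carboxylic acid or a longer chain ending in hydroxyl at the same carbon would bear on that in this assay.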